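The source may hold more compounds than are shown below. What is called first, only, known or untested is meant among the compounds shown, and "the series" means these compounds.

Compound 3 `O=C(OC(C(F)(F)F)C(F)(F)F)N1CCN(Cc2ccc(C(F)(F)F)cc2N2CC3COCC3C2)CC1` gives 17 nM in an assay on brain for inhibition of Monoglyceride lipase (Mus musculus), with a stated time of 30 min (on this read-out higher numbers stand for weaker inhibition and lower numbers for stronger inhibition), the second highest of three numbers. Compound 2 `O=C(OC(C(F)(F)F)C(F)(F)F)N1CCN(Cc2ccc(C(F)(F)F)cc2N2C[C@H]3CC[C@@H](C2)O3)CC1` gives 14 nM and compound 1 `O=C(OC(C(F)(F)F)C(F)(F)F)N1CCN(Cc2ccc(C(F)(F)F)cc2N2CCCCC2)CC1` gives 130 nM. The steps show a 9.3-fold lower number from compound 1 to compound 2 (0.97 log units; beyond the scatter) and a 7.6-fold lower number from compound 1 to compound 3 (0.88 log units; beyond the scatter), while a 1.2-fold higher number from compound 2 to compound 3 (0.08 log units; within the scatter). Compound 4 `CN1CC2CN(c3cc(C(F)(F)F)ccc3CN3CCN(C(=O)OC(C(F)(F)F)C(F)(F)F)CC3)CC2C1` carries a group of 9 heavy atoms (7 carbon, 2 nitrogen; 2 five-membered non-aromatic rings with 1 hetero atom each) in place of a group of 8 heavy atoms (6 carbon, 1 nitrogen, 1 oxygen; 2 five-membered non-aromatic rings with 1 hetero atom each), on an aromatic carbon. For the measured compounds named here, no measured step exchanges the oxygen of this bicycle for a methylated nitrogen, but the one comparison between two bicycles here, from compound 2 to compound 3, stayed within the scatter, and both bicycles beat the single ring of compound 1. Compound 4 is therefore expected to give about 25 nM, within 8 nM to 80 nM. This expectation means a 1.5-fold higher number from compound 3 to compound 4 (0.17 log units; within the scatter), a change not expected to pass beyond the scatter.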

Compound 4, half-maximal inhibitory concentration: 239 nM
Compound 4: middle estimate off by 9.6-fold (0.98 log units), on the low side, outside the stated range (above it).
By their numbers in this assay, from the lowest: compounds 2 and 3 (each within the scatter of the next); then compounds 1 and 4 (each within the scatter of the next).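

In this assay, keeping the two five-membered rings but exchanging the ring oxygen for a nitrogen carrying a methyl is a large step, a 14-fold higher number from compound 3 to compound 4 (1.15 log units; beyond the scatter), and the gap to the other oxygen-containing group is similar, a 17-fold higher number from compound 2 to compound 4 (1.23 log units; beyond the scatter). For the compounds shown here, the two rings alone therefore do not bring the gain over the single ring of compound 1, as a 1.8-fold higher number from compound 1 to compound 4 (0.26 log units; within the scatter) shows. No evidence bearing on this result is available. Still open, from the compounds shown here alone, is whether the methyl or the nitrogen itself matters: the same two rings with an unsubstituted amine nitrogen, or with an acetyl on that nitrogen, would help separate the two.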